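The source may hold more compounds than are shown below. What is called first, only, known or untested is meant among the compounds shown, and "the series" means these compounds.

Of the compounds shown here, three sharing one core have so far been tested in an ADME assay on WI-38 cells (Homo sapiens) for cytotoxicity, read by MTT assay, with a stated time of 3 days; a lower number here means a stronger inhibitor, a higher number a weaker inhibitor. Compound 1 `CCCCCCCCC#Cc1cn(C/C=C\CN2C(=O)c3ccccc3C2=O)c(=O)[nH]c1=O` gives 49000 nM in this assay. Compound 2 `CCCCC#Cc1cn(C/C=C\CN2C(=O)c3ccccc3C2=O)c(=O)[nH]c1=O` gives 28000 nM in this assay. Compound 3 `O=C1c2ccccc2C(=O)N1C/C=C\Cn1cc(C#Cc2ccc(Br)cc2)c(=O)[nH]c1=O` gives 47000 nM in this assay, which places it second highest of the three numbers, though every gap among them lies within the scatter: the smallest is a 1.0-fold lower number from compound 1 to compound 3 (0.02 log units; within the scatter), the larger one is a 1.7-fold higher number from compound 2 to compound 3 (0.22 log units; within the scatter), and the remaining one is a 1.8-fold lower number from compound 1 to compound 2 (0.24 log units; within the scatter).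

The step now considered leads from compound 3 to compound 4 `CCCCc1ccc(C#Cc2cn(C/C=C\CN3C(=O)c4ccccc4C3=O)c(=O)[nH]c2=O)cc1`, a compound not yet measured. The change is butyl in place of bromo on an aromatic carbon; it falls on an aromatic carbon of a six-membered aromatic ring of carbon only, para to a large group. For the measured compounds named here, no measured step alters that position. Going by the values given here, the steps that bear on it are those that reshaped the group at the end of the alkyne, and all of them stayed within the scatter, including the one that shortened the chain and the two that swapped a chain for the 4-bromophenyl. On that basis no step beyond the scatter is expected, a 1.0-fold lower number from compound 3 to compound 4 (0.02 log units; within the scatter). Compound 4 is therefore estimated to give 45000 nM in this assay, expected within 20000 nM to 100000 nM.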

Compound 4, half-maximal inhibitory concentration: 17000 nM
Compound 4: the middle estimate sits 2.6-fold (0.42 log units) above what was measured; the whole stated range lies above it.
By their numbers in this assay, from the lowest: compounds 4, 2, 3 and 1 (each within the scatter of the next, the first and the last beyond it).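

In this assay, for the compounds shown here, butyl in place of bromo on an aromatic carbon, para to a large group, gives a 2.8-fold lower number from compound 3 to compound 4 (0.44 log units; beyond the scatter) and so shows that this position can move the number beyond the scatter, which none of the earlier steps at the end of the alkyne had done. Going by these compounds alone, the group on the triple-bonded carbon also matters more than the earlier compounds suggested: 4-butylphenyl in place of octyl gives a 2.9-fold lower number from compound 1 to compound 4 (0.46 log units; beyond the scatter) and is the other step beyond the scatter, whereas 4-butylphenyl in place of butyl gives a 1.6-fold lower number from compound 2 to compound 4 (0.22 log units; within the scatter) and leaves those two groups without an order. No measurement offered here accounts for the step from bromo to butyl.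

The compounds shown leave open whether the step depends on the chain entering or on the bromo leaving, which a hydrogen, a methyl, a longer chain such as octyl, or an amine on the same aromatic carbon would help to separate. They also leave open whether butyl in place of bromo would give a step of similar size on a different core.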